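The compounds below may be only part of what the source reports. "The series", "measured", "known", "first", "only" and "open" are said of these compounds alone.

Two compounds of a shared core give a first picture. Compound 1 `COc1ccc(CNc2nc(-c3ccccc3C(F)(F)F)nc3ccccc23)cc1` gives, in an assay on a protein complex for inhibition of ubiquitin carboxyl-terminal hydrolase 1/WD repeat-containing protein 48 (Homo sapiens), read by fluorescence (on this read-out higher numbers stand for weaker inhibition and lower numbers for stronger inhibition), a value of 6200 nM. Compound 2 `O=[N+]([O-])c1ccccc1-c1nc(NCc2ccc(-c3cccnc3)cc2)c2ccccc2n1` gives in this assay a value of 7800 nM, and the two numbers lie within the usual scatter of each other, so neither can be ranked against the other. Compound 3 `c1cncc(-c2ccc(CNc3nc(N4CCCC4)nc4ccccc34)cc2)c1` remains to be measured; it differs from compound 2 in one place: pyrrolidin-1-yl in place of 2-nitrophenyl on an aromatic carbon. For the measured compounds named here, no measured pair shows a change of this kind, so no direction is known. A step of a 1.3-fold higher number from compound 2 to compound 3 (0.11 log units; within the scatter) is expected, hardly beyond the scatter. Compound 3 is estimated at 10000 nM, within 3000 nM to 30000 nM.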

Compound 3, half-maximal inhibitory concentration: "not active" (no number reported)
No number was reported for compound 3; the estimate stays without a comparison.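

For the compounds shown here, compound 3 was reported as not active, without a number, so no step from compound 2 to compound 3 can be read. The compounds shown leave open how pyrrolidin-1-yl compares with 2-nitrophenyl in numbers on the shared core. Nothing at hand bears on this result.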